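The source may report more compounds than this note shows. Statements on the series, on what has been measured and on what is new or still open speak of the compounds shown alone.

Three compounds share one core and differ only in the aryl group on the benzyl ether. Compound 1 `Cn1ccnc1[C@@H](CC(=O)O)c1ccc(OCc2cccc(-c3ccccc3S(C)(=O)=O)c2)cc1` gives 23000 nM in an assay on CHO cells for agonist activity at Free fatty acid receptor 1 (Homo sapiens), read by luminescence, with a stated time of 20 s, in the presence of a further agent that is not named here; on this read-out higher numbers stand for an effect only at larger amounts of compound and lower numbers for an effect already at smaller amounts. Compound 2 `Cn1ccnc1[C@@H](CC(=O)O)c1ccc(OCc2cccc(-c3ccc(Cl)cc3Cl)c2)cc1` gives 69 nM, and compound 3 `Cc1ccc(F)cc1-c1cccc(COc2ccc([C@H](CC(=O)O)c3nccn3C)cc2)c1` gives 36 nM, the lowest of the three numbers. The steps of a 330-fold lower number from compound 1 to compound 2 (2.52 log units; beyond the scatter) and a 640-fold lower number from compound 1 to compound 3 (2.81 log units; beyond the scatter) were both large, whereas the step of a 1.9-fold lower number from compound 2 to compound 3 (0.28 log units; within the scatter) stayed within the scatter. Compound 4 `Cn1ccnc1[C@@H](CC(=O)O)c1ccc(OCc2cccc(-c3ccccc3Cl)c2)cc1` carries 2-chlorophenyl in place of 5-fluoro-2-methylphenyl on an aromatic carbon. The two steps leaving compound 1 show that the aryl group matters greatly, yet the step from compound 2 to compound 3 shows two differently substituted aryl groups behaving alike, so a modest step is expected, a 2.2-fold higher number from compound 3 to compound 4 (0.35 log units; beyond the scatter). Compound 4 is therefore estimated at 80 nM, with a range from 25 nM to 300 nM.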

Compound 4, half-maximal effective concentration: 43 nM
For compound 4 the middle estimate is 1.9-fold (0.27 log units) above the measured one, and the stated range covers the measured number.
By their numbers in this assay, from the lowest: compounds 3, 4 and 2 (each within the scatter of the next); then compound 1.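

In this assay, the steps of a 1.2-fold higher number from compound 3 to compound 4 (0.08 log units; within the scatter) and a 1.6-fold lower number from compound 2 to compound 4 (0.21 log units; within the scatter) both stay within the scatter, so 2-chlorophenyl joins the two other aryl groups and the loss of one chloro leaves no readable change. The step of a 530-fold lower number from compound 1 to compound 4 (2.73 log units; beyond the scatter) shows that exchanging the single methylsulfonyl for chloro is enough for a large change. Nothing given here explains these steps. From the compounds shown here alone, it remains open whether plain phenyl would stay with compound 4. Going by these compounds, it also remains open whether an amine or a carboxylic acid on this aryl ring would fall with compound 4 or with compound 1.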